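Bromophenyl Replaces Fluorophenyl on the Triazole Urea

A few compounds are considered here, and "the series" means these few. Any claim that something is new, unique, unknown or untested is made for them only; others in the source may bear on it.

Going by the values given here, in a toxicity assay on MRC5 cells (Homo sapiens) for inhibition, read by MTT assay, with a stated time of 72 h (on this read-out lower numbers stand for stronger inhibition and higher numbers for weaker inhibition), compound 3 `O=C(Nc1cccc(OCc2cn(-c3ccc(F)cc3)nn2)c1)Nc1ccc(Cl)c(C(F)(F)F)c1` gives 4740 nM, the lowest of the three numbers so far, and its gaps to both neighbours lie beyond the scatter. In this assay compound 1 `O=C(Nc1cccc(OCc2cn(-c3ccccc3)nn2)c1)Nc1ccc(Cl)c(C(F)(F)F)c1` gives 18400 nM and compound 2 `CC(C)c1cccc(-n2cc(COc3cccc(NC(=O)Nc4ccc(Cl)c(C(F)(F)F)c4)c3)nn2)c1` gives 21400 nM. The measured steps among them are a 1.2-fold higher number from compound 1 to compound 2 (0.07 log units; within the scatter), a 3.9-fold lower number from compound 1 to compound 3 (0.59 log units; beyond the scatter) and a 4.5-fold lower number from compound 2 to compound 3 (0.65 log units; beyond the scatter). Compound 4 `O=C(Nc1cccc(OCc2cn(-c3cccc(Br)c3)nn2)c1)Nc1ccc(Cl)c(C(F)(F)F)c1` differs from compound 3 by 3-bromophenyl in place of 4-fluorophenyl on an aromatic nitrogen. Among the compounds with values here, no measured step swaps one halogen-bearing phenyl for another, and none introduces a bromine, so the bearing of the known steps is indirect: the isopropyl step a 1.2-fold higher number from compound 1 to compound 2 (0.07 log units; within the scatter) stayed within the scatter, while the fluoro step a 3.9-fold lower number from compound 1 to compound 3 (0.59 log units; beyond the scatter) was modest, so losing the fluoro may give back part of that gain and the bromo adds an unknown. Compound 4 is therefore expected to show a 2.5-fold higher number from compound 3 to compound 4 (0.40 log units; beyond the scatter) in this assay, with an estimated 12000 nM, likely between 4000 nM and 36000 nM.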

Compound 4, half-maximal inhibitory concentration: 11900 nM
The estimate for compound 4 lay 1.0-fold (0.00 log units) above the measured number, and the stated range covers the measured number.
By their numbers in this assay, from the lowest: compound 3; then compounds 4, 1 and 2 (each within the scatter of the next).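

In this assay, 3-bromophenyl in place of 4-fluorophenyl on the aromatic nitrogen gives a 2.5-fold higher number from compound 3 to compound 4 (0.40 log units; beyond the scatter), which leaves compound 3 apart from all three other compounds beyond the scatter. Bromo in place of hydrogen gives a 1.5-fold lower number from compound 1 to compound 4 (0.19 log units; within the scatter) and bromo in place of isopropyl gives a 1.8-fold lower number from compound 2 to compound 4 (0.25 log units; within the scatter), so both steps stay within the scatter, and the bromo does not repeat the step seen with the fluoro of compound 3. Nothing available here explains this difference.

Compound 4 differs from compound 3 in both the halogen and its place on the phenyl ring, so the step does not separate these two changes. The compounds shown also leave open what a chlorophenyl or an aminophenyl group would give on this nitrogen.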